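A few compounds are considered here, and "the series" means these few. Any claim that something is new, unique, unknown or untested is made for them only; others in the source may bear on it.

Compound 1 `CCCCOc1nccnc1C1CN2CCC1CC2`: 24100000 nM
Compound 2 `CCCCCOc1nccnc1C1CN2CCC1CC2`: 9130000 nM
Compound 3 `CCCCCCOc1nccnc1C1CN2CCC1CC2`: 520000 nM

All three compounds were measured in a functional assay on A9L-m1 cells with A9 (Mus musculus) as the target; a higher number here means that more compound is needed for the effect, a lower number that less compound is needed. Compound 3 gives the lowest number of the three, and its gaps to the other two lie beyond the scatter: an 18-fold lower number from compound 2 to compound 3 (1.24 log units; beyond the scatter), and a 46-fold lower number from compound 1 to compound 3 (1.67 log units; beyond the scatter).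

The next compound, compound 4 `CCCCCCCOc1nccnc1C1CN2CCC1CC2`, differs from compound 3 by methyl in place of hydrogen on a saturated chain carbon, six bonds along the chain from an oxygen on an aromatic ring.

Among the compounds with values here, two measured steps bear most directly on this change, since each also puts methyl in place of hydrogen on a saturated chain carbon. Four bonds along the chain from the oxygen, the result was modest: a 2.6-fold lower number from compound 1 to compound 2 (0.42 log units; beyond the scatter). Five bonds along, it was large: an 18-fold lower number from compound 2 to compound 3 (1.24 log units; beyond the scatter). Both steps lowered the number, but their sizes differ widely, and two steps cannot show whether the trend continues or how far. A further fall is therefore expected, with a size somewhere between these two steps. The expected change is a 4.3-fold lower number from compound 3 to compound 4 (0.64 log units; beyond the scatter). The estimated value for compound 4 is 120000 nM, within an expected range of 20000 nM to 600000 nM.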

Compound 4, half-maximal effective concentration: 400000 nM
The estimate for compound 4 lay 3.3-fold (0.52 log units) below the measured number; the range from low to high includes it.
By their numbers in this assay, from the lowest: compounds 4 and 3 (each within the scatter of the next); then compound 2; then compound 1.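

In this assay, methyl in place of hydrogen on a saturated chain carbon, six bonds along the chain from an oxygen on an aromatic ring, gave a 1.3-fold lower number from compound 3 to compound 4 (0.11 log units; within the scatter), so the large fall seen at the preceding chain position did not recur here, and compound 3 and compound 4 cannot be told apart. Both still stand well clear of the shorter-chain compounds, with a 23-fold lower number from compound 2 to compound 4 (1.36 log units; beyond the scatter) and a 60-fold lower number from compound 1 to compound 4 (1.78 log units; beyond the scatter), so the same kind of addition can give a large or an unresolved step depending on where along the chain it falls. The new step also cannot be separated in size from the first methyl step, which leaves the step from compound 2 to compound 3 as the one that stands out among the methyl additions shown: the same change on two cores in this assay, a 2.6-fold lower number (0.42 log units; beyond the scatter) from compound 1 to compound 2 and a 1.3-fold lower number (0.11 log units; within the scatter) from compound 3 to compound 4, 2.0-fold (0.31 log units) apart, within the scatter of two such steps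

The compounds shown leave open whether a longer chain would lower the number further, hold it level or raise it. They also do not show how a branched chain, or an amine or a carboxylic acid at the chain end, would compare with the methyl added here.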